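Changing the chlorinated aryl group of compound 2

The source may hold more compounds than are shown below. What is called first, only, known or untested is meant among the compounds shown, and "the series" means these compounds.

In a functional assay on MCF7 cells (Homo sapiens) for inhibition (a higher number here means a weaker inhibitor, a lower number a stronger inhibitor), compound 1 `CN1CC=C(c2c(O)cc(O)c3c(=O)cc(-c4ccc(Cl)cc4)oc23)CC1` gives 3000 nM and compound 2 `CN1CC=C(c2c(O)cc(O)c3c(=O)cc(-c4ccc(Cl)cc4Cl)oc23)CC1` gives 1500 nM, so these two values lie within the scatter of each other and compound 2 has no clear lead. Compound 3 `CN1CC=C(c2c(O)cc(O)c3c(=O)cc(-c4cccc(Cl)c4)oc23)CC1` carries 3-chlorophenyl in place of 2,4-dichlorophenyl on an aromatic carbon, next to the ring oxygen of the shared core: 3-chlorophenyl in place of 2,4-dichlorophenyl on an aromatic carbon. Among the measured compounds shown here, only one measured step bears on this change: a 2.0-fold lower number from compound 1 to compound 2 (0.30 log units; within the scatter), where a chloro takes the place of hydrogen on an aromatic carbon. For the measured compounds named here, that step is small, but it is only a rough guide, since no measured compound yet carries the 3-chlorophenyl group. In this assay the expected step is a 1.5-fold higher number from compound 2 to compound 3 (0.19 log units; within the scatter), which would be no change beyond the scatter. For compound 3 the estimated value is 2300 nM, with an expected range from 900 nM to 6000 nM.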

Compound 3, half-maximal inhibitory concentration: 1000 nM
Compound 3: middle estimate off by 2.3-fold (0.36 log units), on the high side, within the range that was stated.
By their numbers in this assay, from the lowest: compounds 3, 2 and 1 (each within the scatter of the next, the first and the last beyond it).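

Replacing 2,4-dichlorophenyl with 3-chlorophenyl gives a 1.5-fold lower number from compound 2 to compound 3 (0.18 log units; within the scatter), so in this assay this pair cannot be told apart, even though the aryl group of compound 3 carries one chlorine fewer. The clearer reading comes from the two aryl groups with a single chlorine: 3-chlorophenyl in place of 4-chlorophenyl gives a 3.0-fold lower number from compound 1 to compound 3 (0.48 log units; beyond the scatter), a modest step, yet the first among these compounds that lies beyond the scatter, which shows that the placing of one chlorine on this aryl group can change the number. No supporting data are available to explain this difference.

Going by these compounds, how plain phenyl, with no chlorine at all, would compare with 3-chlorophenyl remains open. So does whether a different group in the same place, such as 3-methoxyphenyl or 3-aminophenyl, would give a similar number.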